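Dropping the Carbamoylamino Link from Compound 3

The compounds below may be only part of what the source reports. "The series", "measured", "known", "first", "only" and "open" are said of these compounds alone.

Measured in a functional assay on CCRF-CEM cells (Homo sapiens) for inhibition, read by MTT assay, with a stated time of 72 h; on this read-out higher numbers stand for weaker inhibition and lower numbers for stronger inhibition:
Compound 1 `COc1cc(NC(C)CCCNC(=O)NNC(=O)Nc2ccc(F)cc2)c2ncccc2c1`: 118000 nM
Compound 2 `COc1cc(NC(C)CCCNC(=O)Nc2ccc(F)cc2)c2ncccc2c1`: 26000 nM
Compound 3 `COc1cc(NC(C)CCCNC(=O)NNC(=O)Nc2cccc(F)c2)c2ncccc2c1`: 98000 nM

Compound 3 belongs with the weaker pair here. The numbers show a 1.2-fold lower number from compound 1 to compound 3 (0.08 log units; within the scatter), and a 3.8-fold higher number from compound 2 to compound 3 (0.58 log units; beyond the scatter). In compound 4 `COc1cc(NC(C)CCCNC(=O)Nc2cccc(C(F)(F)F)c2)c2ncccc2c1`, 3-(trifluoromethyl)phenyl stands in place of ((3-fluorophenyl)carbamoyl)amino on an amide-type nitrogen (3-(trifluoromethyl)phenyl in place of ((3-fluorophenyl)carbamoyl)amino on an amide-type nitrogen). Among the measured compounds shown here, the closest precedent is a 4.5-fold lower number from compound 1 to compound 2 (0.66 log units; beyond the scatter), where 4-fluorophenyl replaced ((4-fluorophenyl)carbamoyl)amino at that same place. For the measured compounds named here, no measured compound carries trifluoromethyl, so its share of the change is unknown. A similar modest fall in the number is therefore expected in this assay. The expected step is a 4.9-fold lower number from compound 3 to compound 4 (0.69 log units; beyond the scatter). For compound 4 the estimated value is 20000 nM, with an expected range of 7000 nM to 55000 nM.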

Compound 4, half-maximal inhibitory concentration: 19000 nM
Estimate against measurement, compound 4: 1.1-fold (0.02 log units) above, and the stated range covers the measured number.
By their numbers in this assay, from the lowest: compounds 4 and 2 (each within the scatter of the next); then compounds 3 and 1 (each within the scatter of the next).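

In this assay, the step seen earlier when the carbamoylamino link was dropped now appears again with a different aryl group: a 5.2-fold lower number from compound 3 to compound 4 (0.71 log units; beyond the scatter), and a 6.2-fold lower number from compound 1 to compound 4 (0.79 log units; beyond the scatter). Among the compounds without the link, 3-(trifluoromethyl)phenyl and 4-fluorophenyl on the amide-type nitrogen cannot be told apart: a 1.4-fold lower number from compound 2 to compound 4 (0.14 log units; within the scatter). No measurement shown here explains these steps. Still open, going by these compounds, is whether a benzyl group or a longer chain carrying an amine, in place of 3-(trifluoromethyl)phenyl at that nitrogen, would keep the number in this range or shift it.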